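The source may report more compounds than this note shows. Statements on the series, on what has been measured and on what is new or still open speak of the compounds shown alone.

Measured so far in a functional assay on MDA-MB-435 cells (Homo sapiens) for cytotoxicity, read by MTT assay, with a stated time of 72 h; on this read-out lower numbers stand for stronger inhibition and higher numbers for weaker inhibition:
Compound 1 `O=C(NCc1ccc(F)cc1)c1nc(Br)c2cccnc2c1NCCCNc1c(C(=O)NCc2ccc(F)cc2)nc(Br)c2cccnc12` gives > 20000 nM, a limit of the assay.
Compound 2 `C[C@@H](Nc1c(C(=O)NCc2ccc(F)cc2)nc(Br)c2cccnc12)c1ccccc1` gives > 20000 nM, also a limit.
Compound 3 `N[C@H]1CC[C@H](NC(=O)c2nc(Br)c3cccnc3c2NCc2ccc(F)cc2)CC1` gives 6600 nM.

Compound 2 thus stands at a limit rather than at a number, sharing that position with compound 1, as the limit of > 20000 nM in this assay, at which 2 of the 3 values shown sit, records. Compound 4 `N[C@H]1CC[C@H](Nc2c(C(=O)NCc3ccc(F)cc3)nc(Br)c3cccnc23)CC1` is not yet measured and differs from compound 2 by one change: 4-aminocyclohexyl in place of 1-phenylethyl on a nitrogen on an aromatic ring. Among the measured compounds shown here, compound 3, the only measured compound with a number, carries the 4-aminocyclohexyl group on another part of the shared core. For the measured compounds named here, with compound 2 at a limit, no measured pair gives the size of this step, so only a modest gain is expected: the step from compound 2 to compound 4 is estimated at an at least 1.6-fold lower number from compound 2 to compound 4 (0.22 log units; that floor lies within the scatter). Compound 4 is expected to give about 12000 nM, within 3000 nM to 40000 nM, in this assay.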

Compound 4, half-maximal inhibitory concentration: 6000 nM
Compound 4: the middle estimate sits 2.0-fold (0.30 log units) above what was measured; the range from low to high includes it.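

In this assay, the substituent on the nitrogen on an aromatic ring proves to matter: 4-aminocyclohexyl in place of 1-phenylethyl gives an at least 3.3-fold lower number from compound 2 to compound 4 (0.52 log units; beyond the scatter). Among the compounds shown here, this replaces a limit with a real number at this position, which no earlier compound had provided. Compound 2 stands at a limit, so the step is only a floor and its full size cannot be read: the limit of > 20000 nM in this assay, at which 2 of the 4 values shown sit.

The compounds shown do not separate the contribution of the amine from that of the cyclohexyl ring. A plain cyclohexyl group or a 4-hydroxycyclohexyl group on this nitrogen would help to tell them apart.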